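Restoring an oxygen to the side chain of compound 3

The compounds below may be only part of what the source reports. "The series", "measured", "known", "first", "only" and "open" are said of these compounds alone.

In a functional assay on the whole organism (spleen, spleen) with Rattus norvegicus as the target (on this read-out lower numbers stand for an effect already at smaller amounts and higher numbers for an effect only at larger amounts of compound), compound 1 `CCCCCCCOc1ccc(CCC(N)(CO)CO)cc1` gives 0.014 mg/kg. Compound 2 `CCCCCCCOc1ccc(CCC(N)(CO)CCC)cc1` gives 7.3 mg/kg in this assay, a change of a 520-fold higher number from compound 1 to compound 2 (2.72 log units; beyond the scatter). Compound 3 `CCCCCCCOc1ccc(CC[C@](N)(CO)CCC)cc1` is reported in this assay only as a limit, > 10 mg/kg, so that the step of an at least 710-fold higher number from compound 1 to compound 3 (2.85 log units; beyond the scatter) is itself a floor. The step of an at least 1.3-fold higher number from compound 2 to compound 3 (0.13 log units; that floor lies within the scatter) shows no clear separation between these two; the one clear observation is that the compound carrying the fact that one of compounds 2 and 3 is drawn with a defined configuration and the other without, at the place where they differ sits at the limit of > 10 mg/kg in this assay, at which 1 of the 3 values shown sits. Compound 3 therefore stands at the weak end of the three values shown, with no number of its own.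

Compound 4 `CCCCCCCOc1ccc(CC[C@@](N)(CO)CCO)cc1` differs from compound 3 by a group of 7 heavy atoms (4 carbon, 1 nitrogen, 2 oxygen; no ring) in place of a group of 7 heavy atoms (5 carbon, 1 nitrogen, 1 oxygen; no ring), on a saturated chain carbon, two bonds along the chain from an aromatic carbon. The step that bears most on this change is a 520-fold higher number from compound 1 to compound 2 (2.72 log units; beyond the scatter), where the loss of a hydroxy at the same kind of carbon cost a large amount; compound 4 brings an oxygen back, though on a longer chain than in compound 1. She therefore expects compound 4 to recover part of that loss and to fall between compound 1 and compound 3, a step of an at least 25-fold lower number from compound 3 to compound 4 (1.39 log units; beyond the scatter), with the estimate for compound 4 in this assay being 0.4 mg/kg, within a range from 0.05 mg/kg to 4 mg/kg.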

Compound 4, dose for 50% inhibition: 0.018 mg/kg
Compound 4: middle estimate off by 22-fold (1.35 log units), on the high side, and the stated range ends above it.
By their numbers in this assay, from the lowest: compounds 1 and 4 (each within the scatter of the next); then compound 2. At a limit, above all of these: compound 3.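

At this saturated chain carbon, two bonds along the chain from an aromatic carbon, exchanging one carbon of the side group for an oxygen gives a 410-fold lower number from compound 2 to compound 4 (2.61 log units; beyond the scatter), while an at least 550-fold lower number from compound 3 to compound 4 (2.74 log units; beyond the scatter) is only a floor, as compound 3 is reported as a limit. The earlier compounds shown here showed only that removing the hydroxy was costly, whereas this result shows that the group of 7 heavy atoms (4 carbon, 1 nitrogen, 2 oxygen) cannot be told apart from the group it replaces in compound 1 in this assay, with a 1.3-fold higher number from compound 1 to compound 4 (0.11 log units; within the scatter) lying within the scatter. Nothing in the data at hand gives a reason for this recovery.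

The compounds shown leave open how far the oxygen can move along the chain, which a longer chain ending in a hydroxy would test, and whether a carboxylic acid or an amine could stand in its place. They also leave open what the configuration at this carbon contributes, as compounds 2 and 3 are not separated and compound 4 appears in one drawn configuration only.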